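This account rests on a few compounds, and the source may have more. Where it says the series, first, only, none or still open, it means among the compounds named here.

Compound 1 `Nc1nc2ccc(OC(F)(F)C(F)(F)F)cc2s1` gives 2.5 mg/kg in a functional assay on the whole organism with Rattus norvegicus as the target; a higher number here means that more compound is needed for the effect, a lower number that less compound is needed. The set also holds (the limit of > 10 mg/kg in this assay, at which 1 of the 3 values shown sits); the compound sitting there is compound 2 `Nc1nc2cc(OC(F)(F)F)ccc2s1`, whose result in this assay is > 10 mg/kg, a limit of the assay and not a number. Compound 3 `N=c1sc2cc(OC(F)(F)F)ccc2n1CCO`, which carries a 2-hydroxyethyl chain on an aromatic nitrogen of the shared core, gives 8 mg/kg in this assay. Among the two numbers obtained, compound 3 stands highest; the nearest number is that of compound 1, and the gap between them lies beyond the usual scatter.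

Compound 4 `CNCCn1c(=N)sc2cc(OC(F)(F)F)ccc21` has not yet been measured in this assay. Its difference from compound 3 is methylamino in place of hydroxy on a saturated chain carbon, two bonds along the chain from an aromatic nitrogen. No step of this kind has been measured among these compounds, so the size of the step can only be judged from the two structures. A small step is expected, with its direction open, and most likely none beyond the scatter. Compound 4 is therefore estimated at 7 mg/kg, between 2.5 mg/kg and 20 mg/kg. That estimate corresponds to an expected step of a 1.1-fold lower number from compound 3 to compound 4 (0.06 log units; within the scatter), and it rests on compound 3 standing at 8 mg/kg.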

Compound 4, dose for half-maximal effect: > 10 mg/kg
Compound 4: only a limit was reported; the forecaster's own chance of this, stated with the estimate: 30%; at least 1.4-fold (0.15 log units) between middle value and limit.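

At this place on the chain, methylamino in place of hydroxy gives an at least 1.2-fold higher number from compound 3 to compound 4 (0.09 log units; that floor lies within the scatter), the only step among these compounds that can be read. Compound 4 holds > 10 mg/kg in this assay, which is a limit of the assay and not a number, so the step has a floor but no upper end, and that floor alone does not set the pair apart. Compound 3 thus remains the only compound shown with a chain on an aromatic nitrogen that has a number, and the result for this change sits at the end of the assay's range: the limit of > 10 mg/kg in this assay, at which 2 of the 4 values shown sit.

As far as these compounds go, whether another group at the end of the chain, such as a primary amine, a dimethylamino group or a carboxylic acid, would give a number close to that of compound 3 stays open, as does the outcome with a longer chain. Also open, from the compounds shown here alone, is how far compound 4 lies beyond its limit, and with that the full size of the step from hydroxy to methylamino.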